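A few compounds are considered here, and "the series" means these few. Any claim that something is new, unique, unknown or untested is made for them only; others in the source may bear on it.

Compound 1 `COc1ccc(-c2cc(CN(c3nc4ccc(F)cc4s3)c3nc4ccc(OC)cc4s3)on2)cc1` and compound 2 `COc1ccc2nc(N(Cc3cc(-c4ccc(Br)cc4)no3)c3nc4ccc(F)cc4s3)sc2c1` are built on the same core and differ in one place: bromo in place of methoxy on an aromatic carbon. In a functional assay on A549 cells (Homo sapiens) for antiproliferative activity, read by MTT assay (on this read-out lower numbers stand for stronger inhibition and higher numbers for weaker inhibition), compound 1 gives 38800 nM, and compound 2 gives 32700 nM, so that the change made a 1.2-fold lower number from compound 1 to compound 2 (0.07 log units; within the scatter). Compound 3 `COc1ccc(-c2cc(CN(c3ncccn3)c3nc4ccccc4s3)on2)cc1` rests on another core, and the difference between the two cores is not broken down here. In this assay compound 3 gives 30500 nM, a number within the scatter of those of compound 1 and compound 2. Compound 4 `Brc1ccc(-c2cc(CN(c3ncccn3)c3nc4ccccc4s3)on2)cc1` carries the same change relative to compound 3, namely (bromo in place of methoxy on an aromatic carbon). Because a 1.2-fold lower number from compound 1 to compound 2 (0.07 log units; within the scatter) stayed within the scatter, a step of similar size, a 1.1-fold lower number from compound 3 to compound 4 (0.05 log units; within the scatter), is expected in this assay. Compound 4 is accordingly estimated at 27000 nM in this assay, with a likely range from 13000 nM to 55000 nM.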

Compound 4, half-maximal inhibitory concentration: 31500 nM
Estimate against measurement, compound 4: 1.2-fold (0.07 log units) below, and the stated range covers the measured number.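

In this assay, bromo in place of methoxy gave a 1.0-fold higher number from compound 3 to compound 4 (0.01 log units; within the scatter), and the same change can now be compared across two cores: the same change on two cores in this assay, a 1.2-fold lower number (0.07 log units; within the scatter) from compound 1 to compound 2 and a 1.0-fold higher number (0.01 log units; within the scatter) from compound 3 to compound 4, 1.2-fold (0.09 log units) apart, within the scatter of two such steps. So in this series the change carried from one core to the other with no step beyond the scatter on either core. This does not show that a larger effect would carry over in the same way, as neither step rises above the scatter, and two cores are a narrow basis for any general rule.

The compounds shown leave open what a different group on the same aromatic carbon, such as an amine or a carboxylic acid, would do in this assay. They also leave open whether such a change would behave alike on both cores.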